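The source may hold more compounds than are shown below. What is called first, only, known or untested is meant among the compounds shown, and "the series" means these compounds.

In an ADME assay for solubility, in simulated intestinal fluid (a higher number here means a more soluble compound, a lower number a less soluble compound), the measured compounds give:

- compound 1 `O=C(Nc1ccc(C(F)(F)F)cc1)N1CCOC2(CCN(C(=O)c3cccc(Cl)c3)CC2)C1`: 21 ug/mL
- compound 2 `Cc1cc(C(=O)N2CCC3(CC2)CN(C(=O)Nc2ccc(OC(F)(F)F)cc2)CCO3)no1`: 83 ug/mL
- compound 3 `O=C1Cc2cc(C(=O)N3CCC4(CC3)CN(C(=O)Nc3ccc(OC(F)(F)F)cc3)CCO4)ccc2N1`: 93 ug/mL

Compound 1 has the lowest of these three numbers, and compound 2 and compound 3 both lie above it by more than the usual scatter. Those two compounds differ from compound 1 in more than one place, so their gaps cannot be pinned on any single group.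

Compound 4 `O=C(Nc1ccc(C(F)(F)F)cc1)N1CCOC2(CCN(C(=O)c3ccccc3Cl)CC2)C1` has not yet been measured. For the measured compounds named here, it holds the same atoms as compound 1, joined differently: 2-chlorophenyl in place of 3-chlorophenyl on a carbonyl carbon is the only change, in short 2-chlorophenyl in place of 3-chlorophenyl on a carbonyl carbon.

Going by the values given here, only one measured step also swaps a group on a carbonyl carbon, and it reads a 1.1-fold higher number from compound 2 to compound 3 (0.05 log units; within the scatter) in this assay as its result. That swap brought in a larger group and stayed within the scatter. It involves no chlorophenyl group, so the data hold no direct measure of the change at hand.

No shift beyond the scatter is therefore expected, and the estimated step is a 1.2-fold higher number from compound 1 to compound 4 (0.08 log units; within the scatter) in this assay as a best guess. For compound 4 the expected value is 25 ug/mL, with an estimated range from 10 ug/mL to 60 ug/mL.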

Compound 4, solubility: 12 ug/mL
Estimate against measurement, compound 4: 2.1-fold (0.32 log units) above, and the stated range covers the measured number.
By their numbers in this assay, from the lowest: compounds 4 and 1 (each within the scatter of the next); then compounds 2 and 3 (each within the scatter of the next).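

In this assay, for the compounds shown here, putting 2-chlorophenyl in place of 3-chlorophenyl on the carbonyl carbon gives a 1.8-fold lower number from compound 1 to compound 4 (0.24 log units; within the scatter), the first direct reading of a chlorophenyl swap at this place. The two compounds hold the same atoms and the same core, so this pair tests only how the chlorophenyl group is joined, something the earlier step between two quite different groups could not test, and here that change does not separate the two compounds beyond the usual scatter of repeated measurements. No separate measurement is available that could explain the two readings.

This is a single pair, so it cannot show whether the same swap would also stay within the scatter on a compound carrying trifluoromethoxy in place of trifluoromethyl, the group found on compound 2 and compound 3. It also leaves open how this assay would respond to very different groups on this carbonyl carbon, such as a plain phenyl ring or a phenyl ring bearing an amine or a carboxylic acid.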